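Swapping the trifluoromethyl of compound 1 for a spirocyclic amine

The compounds below may be only part of what the source reports. "The series", "measured", "known", "first", "only" and "open" are said of these compounds alone.

Compound 1 `O=C(Nc1ccnnc1)c1cc(C(F)(F)F)ccc1OCc1ccccc1` sets the benchmark in this set. In an assay on Sf9 cells for inhibition of Leucine-rich repeat serine/threonine-protein kinase 2 (Homo sapiens), read by TR-FRET, with stated times of 30 min and 2 h (a lower number here means a stronger inhibitor, a higher number a weaker inhibitor), compound 1 gives 15.9 nM, the lowest number among the three measured compounds; compound 3 `O=C(Nc1ccnnc1)c1cc(N2CCC(O)CC2)ccc1OCc1ccccc1` gives 39.8 nM and compound 2 `O=C(Nc1ccnnc1)c1cc(N2C[C@H]3COC[C@H]3C2)ccc1OCc1ccccc1` gives 50.1 nM.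

Compound 4 `CN1CC2(C1)CN(c1ccc(OCc3ccccc3)c(C(=O)Nc3ccnnc3)c1)C2` has not yet been measured. It differs from compound 1 in one place: a group of 8 heavy atoms (6 carbon, 2 nitrogen; 2 four-membered non-aromatic rings with 1 hetero atom each) in place of a group of 4 heavy atoms (1 carbon, 3 fluorine; no ring), on an aromatic carbon.

The two measured steps that bear on this change both start from compound 1 and replace the same trifluoromethyl with a saturated nitrogen-linked ring system. The step of a 3.2-fold higher number from compound 1 to compound 2 (0.50 log units; beyond the scatter) and the step of a 2.5-fold higher number from compound 1 to compound 3 (0.40 log units; beyond the scatter) each moved the number upward by a modest, beyond-scatter margin, and the two ring systems themselves differ only within the scatter, as the step of a 1.3-fold lower number from compound 2 to compound 3 (0.10 log units; within the scatter) shows. The ring system entering in compound 4 is again a saturated nitrogen-linked bicycle, so a similar modest rise in this assay is expected rather than no change or a fall.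

Compound 4 is therefore estimated at 45 nM in this assay, with a likely range from 18 nM to 120 nM, which corresponds to an expected step of a 2.8-fold higher number from compound 1 to compound 4 (0.45 log units; beyond the scatter).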

Compound 4, half-maximal inhibitory concentration: 25.1 nM
Beside the measured number, compound 4's estimate is 1.8-fold (0.25 log units) above it, and the stated range covers the measured number.
By their numbers in this assay, from the lowest: compounds 1, 4, 3 and 2 (each within the scatter of the next, the first and the last beyond it).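

In this assay, the trifluoromethyl of compound 1 can give way to a saturated nitrogen-linked ring system at this position with a 1.6-fold higher number from compound 1 to compound 4 (0.20 log units; within the scatter) as the result, whereas the groups in compound 2 and compound 3 had each stood beyond the scatter from compound 1. The group with two four-membered rings also cannot be separated from the other two ring systems, with a 1.6-fold lower number from compound 3 to compound 4 (0.20 log units; within the scatter) and a 2.0-fold lower number from compound 2 to compound 4 (0.30 log units; within the scatter) as the steps, so the three nitrogen-linked groups form one band despite their different ring sizes and the fact that only compound 3 carries a hydroxyl. Nothing available accounts for this result.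

The compounds shown leave open whether a simple open-chain amine such as dimethylamino, or a morpholine ring, would also stay within the scatter of compound 1 at this position, and what the methyl on the far nitrogen of the group in compound 4 contributes. They also leave open how a carboxylic acid or a nitrile would fare here, and whether the same picture would hold with a group other than benzyloxy on the shared core.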